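Methoxy on the Fused Ring of Compound 1

The source may report more compounds than this note shows. Statements on the series, on what has been measured and on what is new or still open speak of the compounds shown alone.

Among the measured compounds shown here, compound 1 `COc1cc(NC(=O)C2COc3ccccc3C2)ccc1-c1cn[nH]c1` gives 4 nM in an assay on isolated protein for inhibition of Rho-associated protein kinase 2 (Homo sapiens) (a higher number here means a weaker inhibitor, a lower number a stronger inhibitor), the lowest of the two numbers known. Compound 2 `COc1cc(NC(=O)C2COc3ccccc3C2)c(F)cc1-c1cn[nH]c1`, which carries a fluoro in place of hydrogen on an aromatic carbon, gives 17 nM; that step is a 4.3-fold higher number from compound 1 to compound 2 (0.63 log units; beyond the scatter). Compound 3 `COc1ccc2c(c1)CC(C(=O)Nc1ccc(-c3cn[nH]c3)c(OC)c1)CO2` differs from compound 1 by methoxy in place of hydrogen on an aromatic carbon. For the measured compounds named here, the one measured step concerns a different ring, so it bears only loosely on this change, and no shift beyond the scatter is expected: a 1.5-fold higher number from compound 1 to compound 3 (0.18 log units; within the scatter). Compound 3 is therefore estimated at 6 nM, within a range from 2 nM to 20 nM.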

Compound 3, half-maximal inhibitory concentration: 3 nM
Compound 3: middle estimate off by 2.0-fold (0.30 log units), on the high side; measured number inside the range.
By their numbers in this assay, from the lowest: compounds 3 and 1 (each within the scatter of the next); then compound 2.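

On this aromatic carbon of the fused system, methoxy in place of hydrogen gives a 1.3-fold lower number from compound 1 to compound 3 (0.12 log units; within the scatter) in this assay, so the added group leaves no change that can be read. Among the compounds shown here, the earlier step concerned fluoro on the other ring; this is the first evidence that the fused ring can carry a substituent at this position with the number held in the low range. No supporting measurement offers an explanation for this result. Still open, from the compounds shown here alone, is whether an amine, a carboxylic acid or a longer ether chain on this carbon would hold the number as well, and whether methoxy would do so on the other carbons of this ring.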